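The compounds below may be only part of what the source reports. "The series", "measured", "known", "first", "only" and "open" are said of these compounds alone.

In a functional assay on HepG2 cells (Homo sapiens) for cytotoxicity, read by MTT assay, with a stated time of 72 h (a lower number here means a stronger inhibitor, a higher number a weaker inhibitor), compound 1, `NC(=O)c1cnn(-c2ccc(S(N)(=O)=O)cc2)c1N`, reaches only the limit of the assay, > 100000 nM, and so gives no number; the fact that one of the three values sits at this limit is recorded as the limit of > 100000 nM in this assay, at which 1 of the 3 values shown sits. Compound 2, `NS(=O)(=O)c1ccc(-n2ncc3c(=O)[nH]c(-c4ccccc4)nc32)cc1`, gives 77600 nM in this assay, and compound 3, `NS(=O)(=O)c1ccc(-n2ncc3c(=O)[nH]c(-c4ccc(Br)cc4)nc32)cc1`, gives 42600 nM. The change from compound 2 to compound 3, bromo in place of hydrogen on an aromatic carbon, moves the number by a 1.8-fold lower number from compound 2 to compound 3 (0.26 log units; within the scatter), a step that stays within the scatter. Compound 3 therefore holds the lowest of the two numbers shown, though its nearest neighbour, compound 2, lies within the scatter of it, so no order between the two can be claimed.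

Compound 4, `COc1ccc(-c2nc3c(cnn3-c3ccc(S(N)(=O)=O)cc3)c(=O)[nH]2)cc1OC`, is not yet measured. It differs from compound 3 by 3,4-dimethoxyphenyl in place of 4-bromophenyl on an aromatic carbon. Among the compounds with values here, only one measured step bears on this position, the step from compound 2 to compound 3, and it was within the scatter; the present change is larger but of the same kind, a substituted phenyl in place of another phenyl at the same carbon. On that basis the step from compound 3 to compound 4 is expected to be small, a 1.2-fold higher number from compound 3 to compound 4 (0.07 log units; within the scatter), in no clear direction. Compound 4 is thus estimated to give about 50000 nM in this assay, with a range from 18000 nM to 130000 nM.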

Compound 4, half-maximal inhibitory concentration: > 100000 nM
Compound 4: only a limit was reported; the forecaster's own chance of this, stated with the estimate: 25%; middle value at least 2.0-fold (0.30 log units) from the limit.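

Within the data shown here, at the aromatic carbon between two ring nitrogen atoms, 3,4-dimethoxyphenyl in place of 4-bromophenyl gives the first step at this position that lies beyond the scatter, an at least 2.3-fold higher number from compound 3 to compound 4 (0.37 log units; beyond the scatter), so in this assay the number is not indifferent to what the phenyl ring carries. Against the unsubstituted phenyl the reading is weaker, an at least 1.2-fold higher number from compound 2 to compound 4 (0.11 log units; that floor lies within the scatter), and so no firm order can be given between those two compounds. The result for compound 4 is a limit and not a number, which leaves the true size of both steps unknown, and that limit is now shared: the limit of > 100000 nM in this assay, at which 2 of the 4 values shown sit.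

The compounds shown leave open whether one methoxy group alone would give the same step, or whether both are needed. They also leave open how an amine or a carboxylic acid on the phenyl ring would read at this position.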